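The source may report more compounds than this note shows. Statements on the series, on what has been measured and on what is new or still open speak of the compounds shown alone.

Measured in an assay on Ltk cells with metabotropic glutamate receptor 5 (Homo sapiens) as the target, read by fluorescence and calcium flux; a lower number here means a stronger inhibitor, a higher number a weaker inhibitor:
compound 1 `CCOc1cc(C#N)cnc1Nc1cccc(C)n1` gives 46 nM
compound 2 `CCOc1cc(-c2ccccc2C#N)cnc1Nc1cccc(C)n1` gives 37 nM
compound 3 `CCOc1cc(-c2ccc(C)cc2)cnc1Nc1cccc(C)n1` gives 513 nM

Compound 3 carries the highest number of the three; the gaps are an 11-fold higher number from compound 1 to compound 3 (1.05 log units; beyond the scatter) and a 14-fold higher number from compound 2 to compound 3 (1.14 log units; beyond the scatter). Both steps show that the group replacing the cyano shifts the number by a large margin, whereas a 1.2-fold lower number from compound 1 to compound 2 (0.09 log units; within the scatter) shows compound 1 and compound 2 side by side without a difference beyond the scatter. Compound 4 `CCOc1cc(-c2cccnc2)cnc1Nc1cccc(C)n1` differs from compound 3 by pyridin-3-yl in place of 4-methylphenyl on an aromatic carbon. For the measured compounds named here, no measured pair contains pyridin-3-yl, so its effect is not fixed by the data; the steps only show that leaving 4-methylphenyl has gone with much lower numbers. For compound 4 a lower number is expected, of moderate size: a 3.4-fold lower number from compound 3 to compound 4 (0.53 log units; beyond the scatter). Compound 4 is estimated at 150 nM, between 40 nM and 600 nM.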

Compound 4, half-maximal inhibitory concentration: 12 nM
Estimate against measurement, compound 4: 13-fold (1.10 log units) above; measured number outside the range, below it.
By their numbers in this assay, from the lowest: compound 4; then compounds 2 and 1 (each within the scatter of the next); then compound 3.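

In this assay, pyridin-3-yl in place of 4-methylphenyl gives a 43-fold lower number from compound 3 to compound 4 (1.63 log units; beyond the scatter), so an aromatic ring at this position does not by itself go with a high number. The same group also improves on the two earlier substituents, with a 3.1-fold lower number from compound 2 to compound 4 (0.49 log units; beyond the scatter) and a 3.8-fold lower number from compound 1 to compound 4 (0.58 log units; beyond the scatter), which shows that this position allows numbers lower than cyano and 2-cyanophenyl reached. No evidence on the cause of these steps is available.

On these data alone, the change removes the methyl and brings in a ring nitrogen at once, so the share of each remains open. Phenyl or pyridin-4-yl at this position would help separate the two.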